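A Changed Benzyl Group Under a Cytotoxicity Limit

A few compounds are considered here, and "the series" means these few. Any claim that something is new, unique, unknown or untested is made for them only; others in the source may bear on it.

In a toxicity assay on MT2 cells (Homo sapiens) for cytotoxicity (a higher number here means that more compound is tolerated, a lower number that less compound is tolerated), compound 1 (`Cc1nc(C)c([C@H](OC(C)(C)C)C(=O)O)c(N2CCC(C)(C)CC2)c1-c1ccc2c(c1)CCN(Cc1ccc(F)cc1)C2`) gives >= 22000 nM as a limit of the assay and not as a number. Compound 2 (`Cc1nc(C)c([C@H](OC(C)(C)C)C(=O)O)c(N2CCC(C)(C)CC2)c1C1=CCN(CCCc2ccc(F)cc2)CC1`) gives >= 22000 nM as a limit too. Compound 3 (`Cc1nc(C)c([C@H](OC(C)(C)C)C(=O)O)c(N2CCC(C)(C)CC2)c1-c1cnc(OCCc2ccc(F)cc2)nc1`) gives >= 22000 nM as a limit as well. Among the measured compounds shown here, compound 1 therefore stands with the other two: the whole record is the limit of >= 22000 nM in this assay, at which 3 of the 3 values shown sit, and no measured step connects these compounds.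

Compound 4 (`Cc1cccc(Cl)c1CN1CCc2cc(-c3c(C)nc(C)c([C@H](OC(C)(C)C)C(=O)O)c3N3CCC(C)(C)CC3)ccc2C1`) has not yet been measured. It keeps the core of compound 1 and carries 2-chloro-6-methylphenyl in place of 4-fluorophenyl on a saturated chain carbon bound to an amine nitrogen in a ring. Cut one bond further out, the same difference reads 4-fluorobenzyl to 2-chloro-6-methylbenzyl.

The expectation rests on compound 1 and its limit of >= 22000 nM in this assay and on nothing finer than that. No step beyond the usual scatter is expected in either direction, and the estimated step of a number no higher from compound 1 to compound 4 (the limit leaves the size open) is meant in that sense. Compound 4 is expected to read 22000 nM with an estimated range from 15000 nM to 50000 nM and will most likely be reported as a limit again.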

Compound 4, half-maximal cytotoxic concentration: 22500 nM
Compound 4: the middle estimate sits 1.0-fold (0.01 log units) below what was measured, within the range that was stated.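

In this assay, among the compounds shown here, compound 1 gives >= 22000 nM, a limit of the assay and not a number, so no step from compound 1 to compound 4 can be read. The compounds shown leave open what concentration of compound 1 is actually tolerated, and whether 2-chloro-6-methylbenzyl in place of 4-fluorobenzyl changes that concentration at all.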